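This account rests on a few compounds, and the source may have more. Where it says the series, first, only, none or still open, it means among the compounds named here.

Among the compounds with values here, in a functional assay on PC-3 cells (Homo sapiens) (a lower number here means a stronger inhibitor of growth, a higher number a weaker inhibitor of growth), compound 1 `O=S(=O)(/C=C/c1ccc(Br)cc1)Cc1ccc(Nc2ncnc3ccccc23)cc1` gives 42000 nM as the higher of the two numbers so far, and compound 2 `CC(C)(C)c1cc(/C=C/S(=O)(=O)Cc2ccc(Nc3ncnc4ccccc34)cc2)cc(C(C)(C)C)c1O` gives 7000 nM as the lower one. The gap between them lies beyond the usual scatter of repeated measurements, so compound 1 is the weaker growth inhibitor of this pair.

Compound 3 `O=S(=O)(/C=C/c1ccc(F)cc1Cl)Cc1ccc(Nc2ncnc3ccccc23)cc1` has not yet been measured. It keeps the core of compound 1 but carries 2-chloro-4-fluorophenyl in place of 4-bromophenyl on a double-bonded chain carbon bound to a double-bonded chain carbon. Within the data shown here, no two measured compounds differ in one place only, so the data give no direct guide to the size of this step.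

Compound 1 at 42000 nM marks the top of the range seen so far and compound 2 at 7000 nM marks the bottom, so a modest move toward a lower number in this assay is expected, though it may not clear the scatter. The estimated step of a 2.1-fold lower number from compound 1 to compound 3 (0.32 log units; beyond the scatter) is therefore small and uncertain. Compound 3 is expected to give about 20000 nM with an estimated range from 6000 nM to 60000 nM when it is measured.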

Compound 3, concentration for 50% growth inhibition: 100000 nM
Estimate against measurement, compound 3: 5.0-fold (0.70 log units) below; measured number outside the range, above it.
By their numbers in this assay, from the lowest: compound 2; then compound 1; then compound 3.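

In this assay, within the data shown here, this is the first step that can be read at one place alone: on a double-bonded chain carbon bound to a double-bonded chain carbon, replacing 4-bromophenyl with 2-chloro-4-fluorophenyl gives a 2.4-fold higher number from compound 1 to compound 3 (0.38 log units; beyond the scatter) and so weakens growth inhibition. The aromatic ring of carbon stays in place and only the halogens on it differ, so this position responds to which halogens the ring carries and where they sit, at least for this pair. No measurement here explains the loss, and a single step cannot show which part of the swap is responsible.

The change removes bromine and adds both chlorine and fluorine at once, so 4-chlorophenyl, 4-fluorophenyl or 2-chlorophenyl on the same chain would be needed to tell the contribution of each halogen apart. On these data alone, whether a group of another kind, such as a methoxy group, an amine or a carboxylic acid on the phenyl ring, would move growth inhibition in either direction also stays open.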